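This account rests on a few compounds, and the source may have more. Where it says the series, first, only, none or still open, it means among the compounds named here.

Measured in an ADME assay on L1210/0 cells (Mus musculus) for cytotoxicity, with a stated time of 48 h; on this read-out lower numbers stand for stronger inhibition and higher numbers for weaker inhibition:
- Compound 1 `Nc1nc2c(nc(N)n2COCCO)c(=O)[nH]1` gives > 200000 nM, which is a limit.
- Compound 2 `CN(C)c1nc2c(=O)[nH]c(N)nc2n1COCCO` gives > 200000 nM, which is a limit.
- Compound 3 `Nc1nc2c(nc(O)n2COCCO)c(=O)[nH]1` gives > 200000 nM, which is a limit.

Compound 3 therefore has no exact number on this read-out, only its limit of > 200000 nM. The same is true across the series, as the record shows (the limit of > 200000 nM in this assay, at which 3 of the 3 values shown sit).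

The next structure is compound 4 `CNc1nc2c(=O)[nH]c(N)nc2n1COCCO`, which has methylamino in place of hydroxy on an aromatic carbon. Compound 1 carries amino and compound 2 carries dimethylamino at this same place, so three measured steps bear on the change. They are a step that the two limits leave unreadable from compound 1 to compound 3, a step that the two limits leave unreadable from compound 2 to compound 3 and a step that the two limits leave unreadable from compound 1 to compound 2. None of them gives a size or a direction.

Swapping among these groups has so far never produced a readable number in this assay, so the expectation is that compound 4 will also show no measurable inhibition and will most likely be reported as a limit. The step expected on that basis is a step that the limit leaves unreadable from compound 3 to compound 4, with no direction that the data can support. For compound 4 the estimated value is 300000 nM, with an expected range from 150000 nM to 600000 nM.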

Compound 4, half-maximal inhibitory concentration: > 200000 nM
Compound 4 ended at the assay's limit; the forecaster's own chance of this, stated with the estimate: 90%; the middle value does not contradict the limit.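

In this assay, among these compounds, compound 4 gives > 200000 nM, which is a limit, so no step to compound 4 from compound 1, compound 2 or compound 3 can be read. The whole series rests at one value: the limit of > 200000 nM in this assay, at which 4 of the 4 values shown sit.

The compounds shown leave open whether amino, dimethylamino, hydroxy and methylamino differ at all on this read-out.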